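The source may report more compounds than this note shows. Statements on the series, on what has been measured and on what is new or still open speak of the compounds shown alone.

Working notes on the tosylpiperidine series, read in a functional assay on SW1573 cells (Homo sapiens) for antiproliferative activity, read by sulforhodamine B assay, with a stated time of 48 h; on this read-out lower numbers stand for stronger inhibition of growth and higher numbers for weaker inhibition of growth.

Of the compounds shown here, three have been measured so far. Compound 1 `CCCCCCC[C@H]1C[C@H](Cl)CCN1S(=O)(=O)c1ccc(C)cc1` carries a heptyl chain and a chloro group on the saturated ring; in this assay compound 1 gives only a limit, > 100000 nM. Compound 2 `Cc1ccc(S(=O)(=O)N2CCC(Br)CC2)cc1` has a bromo group on the saturated ring and nothing else; in this assay compound 2 likewise reaches only a limit, > 100000 nM. Compound 3 `Cc1ccc(S(=O)(=O)N2CC=C(Cl)CC2)cc1` carries a chloro group on a ring double bond; in this assay compound 3 also gives only a limit, > 100000 nM. Compound 3 therefore cannot be placed relative to compound 1 or compound 2: all three sit at the same limit, as summarised in the limit of > 100000 nM in this assay, at which 3 of the 3 values shown sit. For the measured compounds named here, no step between measured compounds can be quantified, and no pattern beyond the common limit can be drawn.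

The next compound, compound 4 `Cc1ccc(S(=O)(=O)N2CCC(Cl)=CC2CC(C)C)cc1`, differs from compound 3 by isobutyl in place of hydrogen on a saturated ring carbon. Going by the values given here, nothing among the measured compounds shows a substituent on the ring giving anything other than a limit; with its heptyl chain compound 1 still gives only a limit, > 100000 nM. The step from compound 3 to compound 4 is therefore expected to be none beyond the scatter, a number no higher from compound 3 to compound 4 (the limit leaves the size open). Compound 4 is expected to give about 100000 nM, with a range from 30000 nM to 300000 nM, and most likely only a limit again.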

Compound 4, concentration for 50% growth inhibition: 31000 nM
Beside the measured number, compound 4's estimate is 3.2-fold (0.51 log units) above it, and the stated range covers the measured number.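

In this assay, for the compounds shown here, the only step that can be read is isobutyl in place of hydrogen on a saturated ring carbon, next to the ring nitrogen, and it gives an at least 3.2-fold lower number from compound 3 to compound 4 (0.50 log units; beyond the scatter). This ring carbon, two ring bonds from the ring atom that bears a chloro group, is therefore the one place among the compounds shown where a change is seen to bring the read-out off the common limit, leaving compound 4 as the only compound with a number rather than a limit: the limit of > 100000 nM in this assay, at which 3 of the 4 values shown sit. Compound 3 stands at a limit, so the step gives only a lower bound on the size of the change, and compound 1, with its heptyl chain, differs from compound 4 in more than one place and cannot be set against it.

From the compounds shown here alone, it remains open how a methyl group, a longer chain such as hexyl, or a primary amine on the same ring carbon would read. Going by these compounds, it is also open whether the isobutyl step holds when the ring double bond is absent or when bromo takes the place of chloro.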